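The source may hold more compounds than are shown below. What is called first, only, known or untested is meant among the compounds shown, and "the series" means these compounds.

Three measured compounds share one core. In an assay on isolated protein for inhibition of glutathione S-transferase Mu 2 (Homo sapiens), with a stated time of 10 min (on this read-out higher numbers stand for weaker inhibition and lower numbers for stronger inhibition), compound 1 `O=C(CCC(=O)OCCCCCCSc1ccc([N+](=O)[O-])c2nonc12)Nc1ccccc1Cl` gives 330 nM. Compound 2 `COc1ccccc1NC(=O)CCC(=O)OCCCCCCSc1ccc([N+](=O)[O-])c2nonc12` gives 280 nM in this assay, and compound 3 `Cc1ccc(NC(=O)CCC(=O)OCCCCCCSc2ccc([N+](=O)[O-])c3nonc23)cc1` gives 390 nM in this assay. The three numbers all fall within the scatter of one another, so compound 3 cannot be told apart from compound 1 or compound 2: the step of a 1.2-fold higher number from compound 1 to compound 3 (0.07 log units; within the scatter) and the step of a 1.4-fold higher number from compound 2 to compound 3 (0.14 log units; within the scatter) are both small.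

Compound 4 `COc1ccc(NC(=O)CCC(=O)OCCCCCCSc2ccc([N+](=O)[O-])c3nonc23)cc1OC` differs from compound 3 by 3,4-dimethoxyphenyl in place of 4-methylphenyl on an amide-type nitrogen. Within the data shown here, two measured steps bear on this change. The step of a 1.4-fold higher number from compound 2 to compound 3 (0.14 log units; within the scatter) exchanges aryl groups on the same amide-type nitrogen and stays within the scatter, and the step of a 1.2-fold lower number from compound 1 to compound 2 (0.07 log units; within the scatter), which puts a methoxy in place of a chloro on an aromatic carbon, also stays within the scatter. Among the measured compounds shown here, no measured step in this set moves beyond the scatter, so no movement beyond it is expected here either. Compound 4 is therefore expected to give 350 nM in this assay, with a range from 150 nM to 850 nM. The expected step of a 1.1-fold lower number from compound 3 to compound 4 (0.05 log units; within the scatter) lies within the scatter.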

Compound 4, half-maximal inhibitory concentration: 360 nM
Compound 4: middle estimate off by 1.0-fold (0.01 log units), on the low side; the measured number falls inside the stated range.
By their numbers in this assay, from the lowest: compounds 2, 1, 4 and 3 (each within the scatter of the next).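

In this assay, 3,4-dimethoxyphenyl, with 10 heavy atoms and 2 hydrogen-bond acceptors, replaces 4-methylphenyl, with 7 heavy atoms and 0 acceptors, on the amide-type nitrogen and gives a 1.1-fold lower number from compound 3 to compound 4 (0.03 log units; within the scatter) as the result. The exchanges from the other two aryl groups, a 1.3-fold higher number from compound 2 to compound 4 (0.11 log units; within the scatter) and a 1.1-fold higher number from compound 1 to compound 4 (0.04 log units; within the scatter) alike, also stay within the scatter. This position therefore takes a larger aryl group carrying two methoxy groups with no step beyond the scatter, and no measurement at hand offers an explanation for this.

From the compounds shown here alone, all four compounds keep an aryl group on this nitrogen, so it remains open whether a cyclohexyl group there, or an amine or a carboxylic acid on the ring, would move the number beyond the scatter. Also open, going by these compounds, is what a shorter chain in the shared core would do.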